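Swapping Methylsulfanyl for Amino: What to Expect

The source may hold more compounds than are shown below. What is called first, only, known or untested is meant among the compounds shown, and "the series" means these compounds.

Measured compounds:
Compound 1 `CSc1ccc(NC(=O)Nc2cc(C)nc3ccccc23)cc1` gives 16000 nM in an ADME assay on HepG2 cells (Homo sapiens) for cytotoxicity, with a stated time of 72 h; on this read-out higher numbers stand for an effect only at larger amounts of compound and lower numbers for an effect already at smaller amounts.
Compound 2 `Cc1cc(NC(=O)Nc2ccccc2C(N)=O)c2ccccc2n1` gives > 25000 nM in this assay; this is a limit of the assay, not a number.

Within the data shown here, compound 1 stands as the only numerical value shown; the other entry is the limit of > 25000 nM in this assay, at which 1 of the 2 values shown sits. Compound 3 `Cc1cc(NC(=O)Nc2ccc(N)cc2)c2ccccc2n1` differs from compound 1 in one place: amino in place of methylsulfanyl on an aromatic carbon. No step between measured compounds is known, so nothing shown tells how far this change should move this assay; the step is expected to be small, upward or none beyond the scatter. Compound 3 is therefore estimated at 22000 nM (range 9000 nM to 50000 nM), meaning an expected step of a 1.4-fold higher number from compound 1 to compound 3 (0.14 log units; within the scatter).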

Compound 3, half-maximal effective concentration: > 25000 nM
Compound 3: a limit, no number; the forecaster's own chance of this, stated with the estimate: 40%; middle value at least 1.1-fold (0.05 log units) from the limit.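

In this assay, amino in place of methylsulfanyl, on an aromatic carbon para to a large group, gives an at least 1.5-fold higher number from compound 1 to compound 3 (0.19 log units; that floor lies within the scatter). Among these compounds, this is the first step read at this position, and it shows that the change does not lead to a lower number. Compound 3 gives a limit of the assay, not a number, so the step is only a floor, and the series now reads: the limit of > 25000 nM in this assay, at which 2 of the 3 values shown sit.

On these data alone, the true size of the step stays open. So does whether a carboxylic acid or a methoxy group in this place would give a number rather than a limit.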